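The source may report more compounds than this note shows. Statements on the series, on what has been measured and on what is new or still open speak of the compounds shown alone.

Working notes on the bis(trifluoromethyl)benzenesulfonamide series.

Three compounds have numbers in a functional assay on HPAC cells (Homo sapiens) for inhibition, read by MTT assay, with a stated time of 72 h; on this read-out lower numbers stand for stronger inhibition of growth and higher numbers for weaker inhibition of growth. Compound 1 `O=S(=O)(NCCNCc1cccc2ccccc12)c1cc(C(F)(F)F)cc(C(F)(F)F)c1` gives 18000 nM, the highest of the three and therefore the weakest growth inhibition seen so far. Compound 2 `O=S(=O)(NCCCNCc1ccc(Cl)c(C(F)(F)F)c1)c1cc(C(F)(F)F)cc(C(F)(F)F)c1` gives 3000 nM in this assay, and compound 3 `COc1ccc(CNCCCNS(=O)(=O)c2cc(C(F)(F)F)cc(C(F)(F)F)c2)cc1` gives 3000 nM; both sit well away from compound 1, beyond the scatter. For the measured compounds named here, compound 2 and compound 3 differ from compound 1 at more than one place, so no single step links them to it.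

Compound 4 `CC(C)(C)c1ccc(CNCCNS(=O)(=O)c2cc(C(F)(F)F)cc(C(F)(F)F)c2)cc1` has not yet been measured. It differs from compound 1 by 4-(tert-butyl)phenyl in place of naphthalen-1-yl on a saturated chain carbon bound to an amine nitrogen. Going by the values given here, the only measured step of the same kind, an exchange of the aryl group on a saturated chain carbon bound to an amine nitrogen, is no change at the digits printed from compound 2 to compound 3 (within the scatter), which left the number unchanged within the scatter. Among the compounds with values here, that step took place on a different chain from the one in compound 1 and compound 4, so it is an imperfect guide, but it is the only one available.

On that basis the expected step of a 1.4-fold lower number from compound 1 to compound 4 (0.14 log units; within the scatter) is small, without a clear direction beyond the scatter. Compound 4 is therefore estimated at 13000 nM in this assay, with a range from 4000 nM to 40000 nM.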

Compound 4, concentration for 50% growth inhibition: 14000 nM
Compound 4: the middle estimate sits 1.1-fold (0.03 log units) below what was measured; the measured number falls inside the stated range.
By their numbers in this assay, from the lowest: compounds 2 and 3 (each within the scatter of the next); then compounds 4 and 1 (each within the scatter of the next).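

In this assay, the exchange on a saturated chain carbon bound to an amine nitrogen gives a 1.3-fold lower number from compound 1 to compound 4 (0.11 log units; within the scatter), so the chain of compound 1 and compound 4 now has an aryl exchange of its own, and it matches the earlier result on the other chain, no change at the digits printed from compound 2 to compound 3 (within the scatter). This change is also a different kind of exchange: naphthalen-1-yl and 4-(tert-butyl)phenyl each hold 10 heavy atoms, all carbon, yet two six-membered aromatic rings give way to one without a step beyond the scatter, so at this position, in the two pairs shown, the aryl exchanges leave the number where it was. No supporting measurement is available to explain why these numbers stay together.

Among the compounds shown, no pair differs in the chain alone, so the part played by the chain cannot be read from them, even though compound 1 and compound 4 carry higher printed numbers than compound 2 and compound 3. Going by these compounds, it also remains open whether a group of another type at this position, such as a carboxylic acid or a pyridine ring, would give a step beyond the scatter.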